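Primary amine to dimethylamine on a fluorinated core

The source may report more compounds than this note shows. Statements on the series, on what has been measured and on what is new or still open speak of the compounds shown alone.

Of the compounds shown here, two have been measured so far. Compound 1 `NCCn1cc(S(=O)(=O)c2ccccc2)c2ccccc21` gives 25 nM in an assay on HeLa cells for binding affinity to 5-hydroxytryptamine receptor 6 (Homo sapiens); on this read-out lower numbers stand for stronger inhibition and higher numbers for weaker inhibition. Compound 2 `NCCn1cc(S(=O)(=O)c2ccccc2)c2cc(F)ccc21` differs from it by a fluoro in place of hydrogen on an aromatic carbon, and in this assay compound 2 gives 27 nM. Compound 2 stands beside compound 1: the step of a 1.1-fold higher number from compound 1 to compound 2 (0.03 log units; within the scatter) lies within the scatter, so the two cannot be told apart on these numbers.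

Compound 3 `CN(C)CCn1cc(S(=O)(=O)c2ccccc2)c2cc(F)ccc21` is the next compound. It differs from compound 2 by dimethylamino in place of amino on a saturated chain carbon, two bonds along the chain from an aromatic nitrogen. Going by the values given here, no measured step touches this end of the chain: the single step from compound 1 to compound 2 concerns the aromatic fluoro and says nothing about the amine. Without a guide, the expectation for compound 3 is a change no larger than the usual scatter, expressed as a 1.2-fold lower number from compound 2 to compound 3 (0.09 log units; within the scatter). Compound 3 is therefore estimated to give 22 nM in this assay, with a range from 6 nM to 80 nM allowed for the missing information.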

Compound 3, inhibition constant: 44 nM
For compound 3 the middle estimate is 2.0-fold (0.30 log units) below the measured one; measured number inside the range.
By their numbers in this assay, from the lowest: compounds 1, 2 and 3 (each within the scatter of the next).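

Going by these compounds alone, this is the first measured change at the amine end of the chain, and it gives a first reading of how much this place responds to added bulk. In this assay, replacing amino with dimethylamino on the fluorinated core gives a 1.6-fold higher number from compound 2 to compound 3 (0.21 log units; within the scatter), so compound 2 and compound 3 cannot be told apart, even though the group that enters has 3 heavy atoms and 0 hydrogen-bond donors, while the group that leaves has 1 heavy atom and 1 hydrogen-bond donor. No other measurement bears on why the two numbers lie within the scatter of each other.

The compounds shown leave open whether the intermediate methylamino group, or a longer chain such as 3-aminopropyl in place of 2-aminoethyl, would also stay within the scatter of compound 2. They also leave open whether 2-(dimethylamino)ethyl would read the same on the core of compound 1, which has hydrogen where compound 2 has fluoro, since this amine change has been seen on the fluorinated core alone.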